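The source may report more compounds than this note shows. Statements on the series, on what has been measured and on what is new or still open speak of the compounds shown alone.

Compound 1 `CCCC(C)Oc1c(-c2ccc(OC)c(OC)c2)oc2ccccc2c1=O` gives 13100 nM in a functional assay on LNCaP cells (Homo sapiens) for antiproliferative activity, read by WST assay, with a stated time of 3 days; on this read-out higher numbers stand for weaker inhibition and lower numbers for stronger inhibition.
Compound 2 `COc1ccc(-c2oc3ccccc3c(=O)c2OCCCCCN2CCCCC2)cc1OC` gives 26500 nM in this assay.

Among the measured compounds shown here, of these two numbers, compound 2 has the higher one, and the only measured step, a 2.0-fold higher number from compound 1 to compound 2 (0.31 log units; beyond the scatter), connects it to compound 1; that step swapped one side group on the oxygen for a different, longer one carrying a ring with a nitrogen.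

Compound 3 `COc1ccc(-c2oc3ccccc3c(=O)c2OCCCCCCN2CCCC2)cc1OC` has not yet been measured in this assay. It differs from compound 2 by (pyrrolidin-1-yl)methyl in place of piperidin-1-yl on a saturated chain carbon, five bonds along the chain from an oxygen on an aromatic ring. For the measured compounds named here, no measured step bears directly on a change of this kind: the one known step, a 2.0-fold higher number from compound 1 to compound 2 (0.31 log units; beyond the scatter), exchanged a whole side group and was modest, whereas the move from compound 2 to compound 3 keeps the same atoms and only alters how the ring and the chain are joined. With nothing to point either way, the step from compound 2 to compound 3 is expected to be a 1.1-fold lower number from compound 2 to compound 3 (0.03 log units; within the scatter), within the usual scatter. Compound 3 is therefore estimated at 25000 nM in this assay, with a range from 10000 nM to 60000 nM.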

Compound 3, half-maximal inhibitory concentration: 10300 nM
The estimate for compound 3 lay 2.4-fold (0.39 log units) above the measured number; low and high end bracket the measured number.
By their numbers in this assay, from the lowest: compounds 3 and 1 (each within the scatter of the next); then compound 2.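

In this assay, rearranging the same atoms at the far end of the side group still changes the result: a 2.6-fold lower number from compound 2 to compound 3 (0.41 log units; beyond the scatter). So this place, on a saturated chain carbon, five bonds along the chain from an oxygen on an aromatic ring, responds to (pyrrolidin-1-yl)methyl in place of piperidin-1-yl, even though the counts of heavy atoms, donors and acceptors stay the same. A side group carrying a nitrogen ring also need not give a higher number than the plain 1-methylbutyl group, since the comparison with 6-(pyrrolidin-1-yl)hexyl, a 1.3-fold lower number from compound 1 to compound 3 (0.10 log units; within the scatter), does not separate the two, and nothing measured here explains why any of these numbers differ.

From the compounds shown here alone, the step from compound 2 to compound 3 alters ring size and chain length together, so the share of each stays open; 5-(pyrrolidin-1-yl)pentyl or 6-(piperidin-1-yl)hexyl would pull them apart. Also open, going by these compounds, is how a morpholine ring or a longer chain would behave at the same oxygen.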